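Shifting the outer aromatic ring's ether substituent

This account rests on a few compounds, and the source may have more. Where it says the series, first, only, none or still open, it means among the compounds named here.

Two compounds of this series have been examined in an assay on isolated protein with Bile acid receptor (Homo sapiens) as the target; on this read-out lower numbers stand for an effect already at smaller amounts and higher numbers for an effect only at larger amounts of compound. Compound 1 `COC(=O)/C=C/c1cccc(N(Cc2ccc(/C=C/c3ccccn3)cc2)C(=O)C(C)C)c1` gives 310 nM in this assay. Compound 2 `CCOc1cccc(-c2ccc(CN(C(=O)C(C)C)c3cccc(/C=C/C(=O)OC)c3)cc2)c1` carries a 3-ethoxyphenyl where compound 1 has a 2-(pyridin-2-yl)ethenyl. In this assay compound 2 gives 173 nM. Compound 2 therefore stands beside compound 1 rather than apart from it: the step of a 1.8-fold lower number from compound 1 to compound 2 (0.25 log units; within the scatter) is one the usual scatter can account for, so the two numbers cannot be ranked against each other.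

Compound 3 `COC(=O)/C=C/c1cccc(N(Cc2ccc(-c3ccc(OC)cc3)cc2)C(=O)C(C)C)c1` is not yet measured. It differs from compound 2 in one place: 4-methoxyphenyl in place of 3-ethoxyphenyl on an aromatic carbon. Within the data shown here, the only measured step, a 1.8-fold lower number from compound 1 to compound 2 (0.25 log units; within the scatter), concerns a different exchange on the same aromatic carbon and says nothing about moving an ether group around the ring or shortening it by one carbon. Among the measured compounds shown here, with no step that bears directly on this change, and the one neighbouring step within the scatter, the expectation is for no step beyond the scatter in this assay, and compound 3 is estimated at 200 nM (range 80 nM to 500 nM), which means an expected step of a 1.2-fold higher number from compound 2 to compound 3 (0.06 log units; within the scatter).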

Compound 3, half-maximal effective concentration: 97 nM
Compound 3: middle estimate off by 2.1-fold (0.31 log units), on the high side; the measured number falls inside the stated range.
By their numbers in this assay, from the lowest: compounds 3, 2 and 1 (each within the scatter of the next, the first and the last beyond it).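

At this aromatic carbon, para to a large group, 4-methoxyphenyl in place of 3-ethoxyphenyl gives a 1.8-fold lower number from compound 2 to compound 3 (0.25 log units; within the scatter), so in this assay these two ether-bearing phenyl groups cannot be ranked against each other. The exchange of 2-(pyridin-2-yl)ethenyl for 4-methoxyphenyl at the same carbon gives a 3.2-fold lower number from compound 1 to compound 3 (0.50 log units; beyond the scatter), a modest difference but the only one so far at this position that the scatter cannot account for, while compound 2 remains within the scatter of both other compounds. Nothing shown here explains either step.

Between compound 2 and compound 3, the place of the ether on the outer ring and the length of its chain change together, so the two changes cannot be read apart; a 4-ethoxyphenyl or a 3-methoxyphenyl at this carbon would be needed to separate them. As far as these compounds go, it also remains open how a longer alkoxy chain, an amine or a carboxylic acid on that outer ring would read in this assay, and whether any such group would move the number further than the step seen here.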